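Inverting Configuration in a Styryl-Lactone Cinnamate

The compounds below may be only part of what the source reports. "The series", "measured", "known", "first", "only" and "open" are said of these compounds alone.

Measured compounds:
compound 1 `O=C1C[C@@H]2O[C@@H]([C@H](O)c3ccccc3)[C@@H](O)[C@@H]2O1` – 13900 nM
compound 2 `O=C1C[C@@H]2O[C@@H]3[C@@H](O[C@H]3c3ccccc3)[C@@H]2O1` – 25 nM
compound 3 `O=C(/C=C/c1ccccc1)O[C@H](c1ccccc1)[C@H]1O[C@@H]2CC(=O)O[C@@H]2[C@H]1O` – > 100000 nM

The three compounds were tested in a functional assay on HL-60 cells (Homo sapiens) for cytotoxicity, read by MTT assay, with a stated time of 72 h; a higher number here means a weaker inhibitor, a lower number a stronger inhibitor. Compound 2 gives 25 nM, while compound 1 gives 13900 nM. For compound 3 only a limit of the assay is recorded, > 100000 nM, as noted in the limit of > 100000 nM in this assay, at which 1 of the 3 values shown sits; it therefore stands at the weak end of the numbers shown, with no exact value.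

Compound 4 `O=C(/C=C/c1ccccc1)O[C@@H](c1ccccc1)[C@@H]1O[C@H]2CC(=O)O[C@H]2[C@@H]1O` has not yet been measured. It keeps every atom and bond of compound 3 and differs from it only in configuration as drawn: the two compounds have the same atoms and bonds and differ only in configuration as drawn: 5 of 6 stereo elements differ; a stereocentre at a saturated chain carbon is drawn R in compound 3 and S in compound 4; a stereocentre at a saturated ring carbon is drawn S in compound 3 and R in compound 4; a stereocentre at a saturated ring carbon is drawn R in compound 3 and S in compound 4; a stereocentre at a saturated ring carbon is drawn R in compound 3 and S in compound 4. Among the measured compounds shown here, nothing among the measured compounds pairs two structures that differ in one place, so no measured step guides the expectation for this change in configuration alone.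

Because compound 3 sits at the limit (the limit of > 100000 nM in this assay, at which 1 of the 3 values shown sits), the step of an at least 1.6-fold lower number from compound 3 to compound 4 (0.22 log units; that floor lies within the scatter) is expected to be uncertain in direction: the measurement for compound 4 could again end as a limit, or could return a number somewhat below it. Compound 4 is estimated at 60000 nM, within a range from 8000 nM to 150000 nM, with a substantial chance that only a limit is reported.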

Compound 4, half-maximal inhibitory concentration: 1870 nM
Beside the measured number, compound 4's estimate is 32-fold (1.51 log units) above it; measured number below the stated range.
By their numbers in this assay, from the lowest: compound 2; then compound 4; then compound 1. At a limit, above all of these: compound 3.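

In this assay, a change in drawn configuration alone, with no atom or bond entering or leaving, gives an at least 53-fold lower number from compound 3 to compound 4 (1.72 log units; beyond the scatter), the first step among these compounds that can be read at all. From the compounds shown here alone, compound 3 is recorded only as a limit, > 100000 nM, so the true size of this step remains unknown and the printed size is a floor: the limit of > 100000 nM in this assay, at which 1 of the 4 values shown sits. Even so, the step lies beyond the scatter, which shows that in this cinnamate series the drawn configuration alone can separate a compound with a measurable number from one that stays at the limit, and the difference can be attributed to configuration rather than to any change of group: the fact that compounds 3 and 4 differ only in the configuration as drawn.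

The stereo elements differ together between compound 3 and compound 4, so the compounds shown do not tell which of them, alone or in combination, carries the step. They also leave open whether the same change in configuration would give a similar step if the cinnamate ester were replaced by a simple acetate ester, or the free hydroxyl by an amine.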